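Imine series on the shared core: from compound 3 toward compound 4

The compounds below may be only part of what the source reports. "The series", "measured", "known", "first", "only" and "open" are said of these compounds alone.

Measured so far:
compound 1 `COc1cc(/C=N/c2c(C#N)ncn2-c2ccc(F)cc2)cc(OC)c1OC`; in a functional assay on T47D cells (Homo sapiens) for antiproliferative activity, read by MTT assay, with a stated time of 48 h (on this read-out higher numbers stand for weaker inhibition and lower numbers for stronger inhibition), compound 1 gives 13700 nM
compound 2 `COc1ccc(OC)c(/C=N/c2c(C#N)ncn2-c2ccc(F)cc2)c1`; in this assay compound 2 gives 16300 nM
compound 3 `N#Cc1ncn(-c2ccc(F)cc2)c1/N=C/c1ccc([N+](=O)[O-])cc1`; in this assay compound 3 gives 15900 nM

Compound 3 stands second highest of the three numbers. Its nearest neighbour is compound 2, and the gap between them is within the scatter; its furthest neighbour is compound 1, and that gap is within the scatter as well. The three measured values therefore cannot be ranked against one another, and nothing in the set so far separates one imine substituent pattern from another.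

Compound 4 `N#Cc1ncn(-c2ccc(F)cc2)c1/N=C/c1ccc(O)cc1` differs from compound 3 in one place: hydroxy in place of nitro on an aromatic carbon. Among the measured compounds shown here, no pair of measured compounds that differ in a single place is available, so no earlier step of this kind can be drawn on. With every measured number sitting in the same narrow band, the working expectation for the step from compound 3 to compound 4 in this assay is none beyond the scatter, with a weak lean toward a somewhat higher number. Compound 4 is expected to give 18000 nM in this assay, with a range from 7000 nM to 50000 nM. The expected step is a 1.1-fold higher number from compound 3 to compound 4 (0.05 log units; within the scatter).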

Compound 4, half-maximal inhibitory concentration: 20400 nM
For compound 4 the middle estimate is 1.1-fold (0.05 log units) below the measured one; measured number inside the range.
By their numbers in this assay, from the lowest: compounds 1, 3, 2 and 4 (each within the scatter of the next).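

In this assay, hydroxy in place of nitro on an aromatic carbon, para to a large group, gives a 1.3-fold higher number from compound 3 to compound 4 (0.11 log units; within the scatter). Among the compounds shown here, this is the first single-place comparison, and at this position it does not separate the two groups, even though the exchange removes a group with a double bond outside aromatic rings and brings in a hydrogen-bond donor. No measurement is available that could account for this result.

On these data alone, whether an amine or a carboxylic acid on this aromatic carbon would stay within the scatter of compound 4 at 20400 nM, or move the number clearly away from it, remains open. Also open, as far as these compounds go, is whether the same position responds differently when the fluoro substituent on the shared core is exchanged for chloro, since a single comparison on one background cannot show how far this result extends.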